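The source may report more compounds than this note shows. Statements on the series, on what has been measured and on what is new or still open speak of the compounds shown alone.

Measured compounds in a functional assay on MGC-803 cells (Homo sapiens) for inhibition, read by MTT assay, with a stated time of 72 h; on this read-out lower numbers stand for stronger inhibition and higher numbers for weaker inhibition:
compound 1 `CC(C)c1ccc(Nc2nc(SCc3cn(CC(=O)NC(=O)Nc4ccccn4)nn3)nc(-c3ccc(C(C)C)cc3)c2C#N)cc1` gives 15800 nM
compound 2 `COc1cc(-c2nc(SCc3cn(CC(=O)NC(=O)Nc4ccccn4)nn3)nc(Nc3ccc(C(C)C)cc3)c2C#N)cc(OC)c1OC` gives 35500 nM

Among the measured compounds shown here, compound 2 stands at the higher of the two numbers; the one step in the set, a 2.2-fold higher number from compound 1 to compound 2 (0.35 log units; beyond the scatter), lies beyond the scatter. Compound 3 `Cc1ccc(-c2nc(SCc3cn(CC(=O)NC(=O)Nc4ccccn4)nn3)nc(Nc3ccc(C(C)C)cc3)c2C#N)cc1` differs from compound 2 by 4-methylphenyl in place of 3,4,5-trimethoxyphenyl on an aromatic carbon. For the measured compounds named here, the step of a 2.2-fold higher number from compound 1 to compound 2 (0.35 log units; beyond the scatter) is the only one that bears here, and it ran in the opposite sense, the trimethoxyphenyl entering; with that group leaving again for a ring closer to the one in compound 1, a lower number of about that size is expected. Compound 3 is therefore estimated at 18000 nM, range 8000 nM to 40000 nM. That expected step, a 2.0-fold lower number from compound 2 to compound 3 (0.29 log units; within the scatter), would roughly return to the level of compound 1.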

Compound 3, half-maximal inhibitory concentration: 19300 nM
Compound 3: the middle estimate sits 1.1-fold (0.03 log units) below what was measured; the measured number falls inside the stated range.
By their numbers in this assay, from the lowest: compounds 1, 3 and 2 (each within the scatter of the next, the first and the last beyond it).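

In this assay, 4-methylphenyl in place of 3,4,5-trimethoxyphenyl gives a 1.8-fold lower number from compound 2 to compound 3 (0.26 log units; within the scatter), a step within the scatter. Methyl in place of isopropyl gives a 1.2-fold higher number from compound 1 to compound 3 (0.09 log units; within the scatter), also within the scatter, so compounds 1 and 3 cannot be separated at this position. No evidence on hand accounts for these numbers. Going by these compounds, whether a ring carrying an amine or a carboxylic acid here would separate from these compounds stays open. On these data alone, the role of the (4-isopropylphenyl)amino group also stays open, since all three compounds share it.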